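The compounds below may be only part of what the source reports. "The series", "measured", "known", "first", "only" and "open" are said of these compounds alone.

The measured compounds:

Compound 1, `CCCn1c(=O)n(CCO)c(=O)c2[nH]cnc21`, gives 50000 nM in an assay on Cerebral cortex for binding affinity to adenosine receptor A1 (Cavia porcellus), read by radioligand binding; on this read-out lower numbers stand for stronger inhibition and higher numbers for weaker inhibition.
Compound 2, `CCCn1c(=O)n(CCCO)c(=O)c2[nH]cnc21`, gives 12000 nM in this assay.
Compound 3, `CCCn1c(=O)n(C)c(=O)c2c1ncn2CCO`, gives 41400 nM in this assay.

Compounds 1 and 2 differ in one place only, (hydroxymethyl in place of hydroxy on a saturated chain carbon, two bonds along the chain from an aromatic nitrogen), and this change brought a 4.2-fold lower number from compound 1 to compound 2 (0.62 log units; beyond the scatter). Compound 3 shares no single counted difference with compound 1; the difference between the two cores is not broken down here. Its value lies within the scatter of the value of compound 1, and the gap to compound 2 is beyond the scatter.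

Compound 4, `CCCn1c(=O)n(C)c(=O)c2c1ncn2CCCO`, has not yet been measured. It is related to compound 3 by the same change, (hydroxymethyl in place of hydroxy on a saturated chain carbon, two bonds along the chain from an aromatic nitrogen), made on the core of compound 3 instead of the core of compound 1. Within the data shown here, the step from compound 3 to compound 4 is expected to be a 3.5-fold lower number from compound 3 to compound 4 (0.54 log units; beyond the scatter), resting on the single earlier instance, a 4.2-fold lower number from compound 1 to compound 2 (0.62 log units; beyond the scatter), with the caution that one precedent on a different core gives no firm ground. Compound 4 is therefore estimated at 12000 nM, expected to fall between 4000 nM and 35000 nM.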

Compound 4, inhibition constant: 112000 nM
The estimate for compound 4 lay 9.3-fold (0.97 log units) below the measured number, and the stated range ends below it.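

In this assay, going from 2-hydroxyethyl to 3-hydroxypropyl on the core of compound 3 gave a 2.7-fold higher number from compound 3 to compound 4 (0.43 log units; beyond the scatter) and so ran the opposite way to the earlier instance on the core of compound 1. This shows that the step from this change cannot simply be carried from one core to another in this series, although it does not show what in the two cores sets the direction, and with one pair on each core neither direction can be called typical of its core. The two steps stand apart by more than the scatter allows: the same change on two cores in this assay, a 4.2-fold lower number (0.62 log units; beyond the scatter) from compound 1 to compound 2 and a 2.7-fold higher number (0.43 log units; beyond the scatter) from compound 3 to compound 4, 11-fold (1.05 log units) apart, beyond the scatter of two such steps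

The compounds shown leave open whether a longer chain, such as 4-hydroxybutyl, would extend either direction on either core. They also leave open whether the split between the cores would persist with a methoxy group or an amine at the chain end in place of the hydroxy.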